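A few compounds are considered here, and "the series" means these few. Any claim that something is new, unique, unknown or untested is made for them only; others in the source may bear on it.

Compound 1 `COc1ccccc1NC(=O)Nc1cccc(CNc2nccnc2Cl)c1`: in a functional assay on T-24 cells (Homo sapiens) for antiproliferative activity, read by MTT assay, with a stated time of 48 h (on this read-out lower numbers stand for stronger inhibition and higher numbers for weaker inhibition), compound 1 gives 10400 nM.
Compound 2 `Cc1cccc(NC(=O)Nc2cccc(CNc3nccnc3Cl)c2)c1`: compound 2 gives 9570 nM.
Compound 3 `O=C(Nc1cccc(CNc2nccnc2Cl)c1)Nc1ccc(Cl)cc1Cl`: compound 3 gives 5740 nM.

Of these three numbers, compound 1 carries the highest, but neither of the other two compounds stands apart from it beyond the scatter. Compound 4 `CCc1ccccc1NC(=O)Nc1cccc(CNc2nccnc2Cl)c1` differs from compound 1 by ethyl in place of methoxy on an aromatic carbon. The measured steps that bear on this change are the ones that swap the group on the amide-type nitrogen: a 1.1-fold lower number from compound 1 to compound 2 (0.04 log units; within the scatter) and a 1.8-fold lower number from compound 1 to compound 3 (0.26 log units; within the scatter), both within the scatter. On that basis no step beyond the scatter is expected in this assay for compound 4 in either direction, so the expected step is a 1.2-fold lower number from compound 1 to compound 4 (0.06 log units; within the scatter). Compound 4 is therefore estimated at 9000 nM, with a range from 4500 nM to 18000 nM.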

Compound 4, half-maximal inhibitory concentration: 8720 nM
Compound 4: middle estimate off by 1.0-fold (0.01 log units), on the high side; the measured number falls inside the stated range.
By their numbers in this assay, from the lowest: compounds 3, 4, 2 and 1 (each within the scatter of the next).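

In this assay, among the compounds shown here, ethyl in place of methoxy on this aromatic carbon, ortho to a large group, takes away a hydrogen-bond acceptor, yet the only step confined to this position is small (a 1.2-fold lower number from compound 1 to compound 4 (0.08 log units; within the scatter)). The steps from the two other aryl ureas also stay inside the scatter (a 1.5-fold higher number from compound 3 to compound 4 (0.18 log units; within the scatter); a 1.1-fold lower number from compound 2 to compound 4 (0.04 log units; within the scatter)), so compound 4 does not stand apart from them. Nothing measured here explains this.

From the compounds shown here alone, it remains open whether an amine, a hydroxyl or a longer chain such as propyl on this carbon would move the number beyond the scatter.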